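The source may hold more compounds than are shown below. What is called first, only, known or untested is meant among the compounds shown, and "the series" means these compounds.

Compound 1, `O=C(/C=C/c1ccccc1)OCC1COCCOCCOCCOCCOCCO1`, and compound 2, `CC/C=C/CC(=O)OCC1COCCOCCOCCOCCOCCO1`, share one core and differ only in the group on the ester carbonyl. In a functional assay on WiDr cells (Homo sapiens) for inhibition, read by sulforhodamine B assay, with a stated time of 48 h (on this read-out lower numbers stand for stronger inhibition of growth and higher numbers for weaker inhibition of growth), compound 1 gives only a limit of the assay, > 100000 nM. In this assay compound 2 likewise gives only a limit, > 100000 nM. Within the data shown here, the one measured step, a step that the two limits leave unreadable from compound 1 to compound 2, puts pent-2-en-1-yl in place of 2-phenylethenyl on a carbonyl carbon, and its size cannot be read because both ends sit at the limit of > 100000 nM in this assay, at which 2 of the 2 values shown sit. Compound 2 thus has no place on a scale of numbers: both values shown are limits. Compound 3, `O=C(OCC1COCCOCCOCCOCCOCCO1)c1cccnc1`, differs from compound 2 by pyridin-3-yl in place of pent-2-en-1-yl on a carbonyl carbon. Among the measured compounds shown here, the only step that bears on this change is the unreadable one, so nothing measured points to a direction or a size for compound 3 in this assay. For the measured compounds named here, no measured compound inhibits growth within the range the assay can report. Compound 3 is expected to remain at the limit as well, with an estimated value of 150000 nM (between 40000 nM and 600000 nM), which means an expected step that the limit leaves unreadable from compound 2 to compound 3.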

Compound 3, concentration for 50% growth inhibition: > 100000 nM
Compound 3: no number, only a limit; the forecaster's own chance of this, stated with the estimate: 85%; the middle value lies beyond the limit too.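

No new step can be read among compound 1, compound 2 and compound 3, because all three give a limit rather than a number: the limit of > 100000 nM in this assay, at which 3 of the 3 values shown sit. The compounds shown leave open whether any group on the carbonyl carbon of the shared core brings growth inhibition within the range that this assay can report.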